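The source may report more compounds than this note shows. Statements on the series, on what has been measured and on what is new or still open speak of the compounds shown alone.

Working notes on the series.

Compound 1, `CC1=C(O)c2c(oc(-c3ccc(C)cc3)cc2=O)C(C)(C)C1=O`, gives 22.5 ug/mL in a functional assay on KB cells (Homo sapiens) for cytotoxicity, read by sulforhodamine B assay; on this read-out lower numbers stand for an effect already at smaller amounts and higher numbers for an effect only at larger amounts of compound. Compound 2, `CCc1ccc(-c2cc(=O)c3c(o2)C(C)(C)C(=O)C(C)=C3O)cc1`, gives 20 ug/mL in this assay. The difference between the two is methyl in place of hydrogen on a saturated chain carbon bound to an aromatic carbon, and the step measured is a 1.1-fold lower number from compound 1 to compound 2 (0.05 log units; within the scatter). Compound 3, `CCC1=C(O)c2c(oc(-c3ccc(C)cc3)cc2=O)C(CC)(CC)C1=O`, gives 13.8 ug/mL in this assay; the difference between its core and the core of compound 1 is not broken down here, and the values of compound 3 and compound 2 lie within the scatter of each other, as do those of compound 3 and compound 1.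

Compound 4, `CCC1=C(O)c2c(oc(-c3ccc(CC)cc3)cc2=O)C(CC)(CC)C1=O`, is not yet measured. It differs from compound 3 by methyl in place of hydrogen on a saturated chain carbon bound to an aromatic carbon, the same change as that from compound 1 to compound 2, at the same place. Because of a 1.1-fold lower number from compound 1 to compound 2 (0.05 log units; within the scatter) the step expected is a 1.1-fold lower number from compound 3 to compound 4 (0.04 log units; within the scatter), a shift that stays within the scatter. On that basis compound 4 is estimated at 12.5 ug/mL in this assay. For compound 4 the expected range runs from 7 ug/mL to 25 ug/mL.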

Compound 4, concentration for half-maximal effect: 8 ug/mL
For compound 4 the middle estimate is 1.6-fold (0.19 log units) above the measured one; measured number inside the range.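

In this assay the change from 4-methylphenyl to 4-ethylphenyl gives a 1.7-fold lower number from compound 3 to compound 4 (0.24 log units; within the scatter), so the step stays within the scatter on the core of compound 3, as it does on the core of compound 1. Set side by side, the two steps do not differ beyond what repeated measurement allows: the same change on two cores in this assay, a 1.1-fold lower number (0.05 log units; within the scatter) from compound 1 to compound 2 and a 1.7-fold lower number (0.24 log units; within the scatter) from compound 3 to compound 4, 1.5-fold (0.19 log units) apart, within the scatter of two such steps. This shows that the change carries from one core to the other with no detectable difference in this read-out, but it does not show a real effect of the ethyl group on either core, and two cores give no rule for the wider series.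

The compounds shown leave open whether a longer chain such as propyl or butyl, or an amine or a carboxylic acid, in place of the ethyl would move the number beyond the scatter. They also leave open what each chain on the core contributes, since compound 1 and compound 3 differ in more than one place.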